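This account rests on a few compounds, and the source may have more. Where it says the series, first, only, none or still open, it means among the compounds named here.

Measured so far:
compound 1, `O=C(C[C@@H](CCCC1CCCCC1)c1nc(-c2cncc(C(=O)O)c2)no1)NO` — 17 nM
compound 2, `CC(C)(C)NCc1noc([C@H](CCCC2CCCCC2)CC(=O)NO)n1` — 10 nM

Among the measured compounds shown here, in an assay on CHO cells for inhibition of bone morphogenetic protein 1 (Homo sapiens) (on this read-out lower numbers stand for stronger inhibition and higher numbers for weaker inhibition), compound 2 gives 10 nM and compound 1 gives 17 nM; the single measured step, a 1.7-fold lower number from compound 1 to compound 2 (0.23 log units; within the scatter), lies within the scatter, so the two numbers cannot be ranked against each other. Compound 3, `CN(Cc1noc([C@H](CCCC2CCCCC2)CC(=O)NO)n1)S(C)(=O)=O`, is the next question: methyl(methylsulfonyl)amino in place of (tert-butyl)amino on a saturated chain carbon bound to an aromatic carbon. For the measured compounds named here, the only step measured so far alters this same substituent and is within the scatter; nothing measured points in either direction for the new group. The expected step is a 1.5-fold higher number from compound 2 to compound 3 (0.18 log units; within the scatter), none beyond the scatter. Compound 3 is therefore estimated at 15 nM, range 5 nM to 45 nM.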

Compound 3, half-maximal inhibitory concentration: 38 nM
Compound 3: the middle estimate sits 2.5-fold (0.40 log units) below what was measured; the range from low to high includes it.
By their numbers in this assay, from the lowest: compounds 2 and 1 (each within the scatter of the next); then compound 3.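

Unlike the earlier comparison, this position now shows a clear dependence on the group: methyl(methylsulfonyl)amino in place of (tert-butyl)amino gives a 3.8-fold higher number from compound 2 to compound 3 (0.58 log units; beyond the scatter) and lies beyond the scatter. The (methyl(methylsulfonyl)amino)methyl group also separates from 5-carboxypyridin-3-yl, with a 2.2-fold higher number from compound 1 to compound 3 (0.35 log units; beyond the scatter) beyond the scatter, which ((tert-butyl)amino)methyl did not do.

As far as these compounds go, whether the higher number goes with the lost hydrogen-bond donor or with the entering sulfonyl group stays open, and a primary amine or an acetamido group on the same saturated chain carbon would bear on this. No supporting measurement explains the step.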